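Extending the aryl ether of compound 2 toward a larger side chain

The source may report more compounds than this note shows. Statements on the series, on what has been measured and on what is new or still open speak of the compounds shown alone.

Compound 1 `COc1ccc2c(c1)C(n1ccccc1=O)=CC(C)(C)O2` gives 5.99 in a functional assay (trachea) with Rattus norvegicus as the target; a higher number here means a more potent compound, by a factor of ten per unit of this negative logarithm, a lower number a less potent compound; compound 2 `CC(=O)Oc1ccc2c(c1)C(n1ccccc1=O)=CC(C)(C)O2` gives 4.97, the lowest of the two numbers, with the change of a number 1.02 log units lower from compound 1 to compound 2 (beyond the scatter). Compound 3 `CC1(C)C=C(n2ccccc2=O)c2cc(OCC(=O)c3ccccc3)ccc2O1` differs from compound 2 by benzoylmethyl in place of acetyl on an oxygen on an aromatic ring. Among the compounds with values here, the only measured step, a number 1.02 log units lower from compound 1 to compound 2 (beyond the scatter), alters the same oxygen, so it bears on this change only loosely, and its direction is not a guide here. Compound 3 is therefore expected to lie between the two measured numbers, near 5.6, with a range of 4.8 to 6.4, meaning a step of a number 0.63 log units higher from compound 2 to compound 3 (beyond the scatter).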

Compound 3, logarithm of the reciprocal of the active concentration, log(1/C): 4.69
Compound 3: middle estimate off by 0.91 log units, on the high side; measured number below the stated range.
By their numbers in this assay, from the lowest: compounds 3 and 2 (each within the scatter of the next); then compound 1.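

In this assay, exchanging acetyl for benzoylmethyl on the oxygen on the aromatic ring gives a number 0.28 log units lower from compound 2 to compound 3 (within the scatter), so the two groups cannot be told apart here. Set against the methyl ether, benzoyl in place of hydrogen on the chain carbon gives a number 1.30 log units lower from compound 1 to compound 3 (beyond the scatter), so compound 3 joins compound 2 well apart from compound 1. Nothing measured here explains this result. Still open, from the compounds shown here alone, is whether a plain longer alkyl chain with no carbonyl, or a chain ending in an amine or a carboxylic acid, would stay with compound 1 or with compounds 2 and 3.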